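The source may hold more compounds than are shown below. What is called first, only, known or untested is meant among the compounds shown, and "the series" means these compounds.

Measured so far in a functional assay on GTL 16 cells for antiproliferative activity against GTL 16 cell line (Homo sapiens), read by CCK-8 assay, with a stated time of 72 h; a lower number here means a stronger inhibitor, a higher number a weaker inhibitor:
Compound 1, `O=C(Nc1cccc(-c2oc3cc(-c4ccc(F)cc4)ccc3c(=O)c2O)c1)c1ccccc1F`, gives 17400 nM.
Compound 2, `COc1ccc(C(=O)Nc2cccc(-c3oc4cc(-c5ccc(F)cc5)ccc4c(=O)c3O)c2)cc1`, gives 21100 nM.
Compound 3, `O=C(Nc1cccc(-c2oc3cc(-c4ccc(F)cc4)ccc3c(=O)c2O)c1)c1ccc(C(F)(F)F)cc1`, gives 33000 nM.

Compound 3 carries the highest of the three numbers, yet its gaps to the others, a 1.6-fold higher number from compound 2 to compound 3 (0.19 log units; within the scatter) and a 1.9-fold higher number from compound 1 to compound 3 (0.28 log units; within the scatter), both lie within the scatter, so on these data the three compounds cannot be told apart in this assay. Compound 4, `O=C(Nc1cccc(-c2oc3cc(-c4ccc(F)cc4)ccc3c(=O)c2O)c1)c1cccc(F)c1`, differs from compound 3 in one place: 3-fluorophenyl in place of 4-(trifluoromethyl)phenyl on a carbonyl carbon. The measured steps that bear on this are the two exchanges of the ring on the carbonyl carbon, a 1.2-fold higher number from compound 1 to compound 2 (0.08 log units; within the scatter) and a 1.9-fold higher number from compound 1 to compound 3 (0.28 log units; within the scatter), and the single-group change on that ring, a 1.6-fold higher number from compound 2 to compound 3 (0.19 log units; within the scatter); none of them moved the number beyond the scatter. Compound 1, which carries 2-fluorophenyl on the carbonyl carbon, is the nearest relative of compound 4 in this set. A step no larger than the scatter is therefore expected, a 1.7-fold lower number from compound 3 to compound 4 (0.22 log units; within the scatter). Compound 4 is estimated at 20000 nM, between 9000 nM and 45000 nM, in this assay.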

Compound 4, half-maximal inhibitory concentration: 15800 nM
The estimate for compound 4 lay 1.3-fold (0.10 log units) above the measured number; measured number inside the range.
By their numbers in this assay, from the lowest: compounds 4, 1, 2 and 3 (each within the scatter of the next, the first and the last beyond it).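

In this assay, among the compounds shown here, putting 3-fluorophenyl in place of 4-(trifluoromethyl)phenyl on the carbonyl carbon gives the only step in this set that passes the scatter, a modest one: a 2.1-fold lower number from compound 3 to compound 4 (0.32 log units; beyond the scatter). The other two new steps, a 1.3-fold lower number from compound 2 to compound 4 (0.13 log units; within the scatter) and a 1.1-fold lower number from compound 1 to compound 4 (0.04 log units; within the scatter), stay within the scatter, so compound 4 cannot be told apart from compound 2, nor from compound 1, which carries 2-fluorophenyl instead of 3-fluorophenyl. Nothing measured here explains why the step from compound 3 alone passes the scatter.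

Every group shown on this carbonyl carbon is a substituted phenyl ring carrying fluorine, trifluoromethyl or methoxy. As far as these compounds go, what a ring bearing an amine or a carboxylic acid, or a pyridine ring in place of the phenyl, would do to the number remains open.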